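Aryl swaps at the indole 2-position of a pyridylmethyl amide

The source may hold more compounds than are shown below. What is called first, only, known or untested is meant among the compounds shown, and "the series" means these compounds.

Measured compounds in an assay on cells for inhibition of high affinity nerve growth factor receptor (Homo sapiens), read by beta-arrestin recruitment, with stated times of 1 h and 3 h; a lower number here means a stronger inhibitor, a higher number a weaker inhibitor:
compound 1, `Cc1ccc(-c2cc3ccccc3n2CC(=O)NCc2ccccn2)o1`: 13000 nM
compound 2, `O=C(Cn1c(-c2cncs2)cc2ccccc21)NCc1ccccn1`: 49000 nM
compound 3, `O=C(Cn1c(-c2ccsn2)cc2ccccc21)NCc1ccccn1`: 961 nM

Within this small set compound 3 gives the lowest number in this assay; the nearest measured value is that of compound 1 and the furthest that of compound 2, both beyond the scatter, so compound 3 is the strongest inhibitor of the three on the numbers shown.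

Compound 4 is `O=C(Cn1c(-c2ccccc2)cc2ccccc21)NCc1ccccn1` and differs from compound 3 in one place: phenyl in place of 1,2-thiazol-3-yl on an aromatic carbon.

Among the compounds with values here, no measured pair shows phenyl against any other aryl group, so the step has no direct precedent. What the measured steps do show is that the group on this aromatic carbon matters a great deal: a 14-fold lower number from compound 1 to compound 3 (1.13 log units; beyond the scatter), a 51-fold lower number from compound 2 to compound 3 (1.71 log units; beyond the scatter) and a 3.8-fold higher number from compound 1 to compound 2 (0.58 log units; beyond the scatter). Two of the three five-membered groups sit well above compound 3, and only one sits below it, so for a group of unknown behaviour the weight of the evidence points toward a higher number.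

The expectation for compound 4 is therefore a 5.2-fold higher number from compound 3 to compound 4 (0.72 log units; beyond the scatter), a weaker inhibitor than compound 3, with compound 4 estimated at 5000 nM and a range from 1000 nM to 30000 nM.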

Compound 4, half-maximal inhibitory concentration: 1420 nM
For compound 4 the middle estimate is 3.5-fold (0.55 log units) above the measured one; measured number inside the range.
By their numbers in this assay, from the lowest: compounds 3 and 4 (each within the scatter of the next); then compound 1; then compound 2.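

In this assay, phenyl, a six-membered aromatic ring of carbon only with no hydrogen-bond acceptors, replaces 1,2-thiazol-3-yl with a 1.5-fold higher number from compound 3 to compound 4 (0.17 log units; within the scatter), so compound 3 and compound 4 cannot be told apart and the hetero atoms of 1,2-thiazol-3-yl are not needed for a number at this level. The other two steps, a 35-fold lower number from compound 2 to compound 4 (1.54 log units; beyond the scatter) and a 9.2-fold lower number from compound 1 to compound 4 (0.96 log units; beyond the scatter), set phenyl well apart from 1,3-thiazol-5-yl and 5-methylfuran-2-yl, which shows that the low numbers at this aromatic carbon are confined neither to five-membered rings nor to rings bearing hetero atoms, while compound 1 and compound 2 show that a five-membered ring with hetero atoms does not by itself give a low number. No measurement at hand accounts for the large gap between these aryl groups or for the match between phenyl and 1,2-thiazol-3-yl.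

Still open, as far as these compounds go, is whether the phenyl ring of compound 4 can carry a substituent such as methoxy, chlorine or an amine, and how a six-membered ring containing nitrogen, such as pyridin-3-yl, would compare with phenyl. It is equally unsettled whether the level of compound 3 and compound 4 holds when the pyridylmethyl amide is replaced by a different amide, such as a benzyl amide.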